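The compounds below may be only part of what the source reports. "The series", "measured", "known", "first", "only" and "open" are said of these compounds alone.

The account concerns three close relatives built on a shared core: compound 1 `ClCc1ccc(Cn2cnc3c(Cl)ncnc32)cc1`, compound 2 `ClCc1ccccc1Cn1cnc2c(Cl)nc(Cl)nc21` and compound 3 `ClCc1ccccc1Cn1cnc2c(Cl)ncnc21`. The single read-out is a functional assay on RPMI-8226 cells (Homo sapiens) for cytotoxicity, read by sulforhodamine B assay, with a stated time of 48 h; a higher number here means that more compound is tolerated, a lower number that less compound is tolerated. In that assay compound 1 gives > 100000 nM, which is a limit of the assay rather than a number. For compound 2 the outcome is "not determined" (no result reported), so no figure places it anywhere. Going by the values given here, of the two entries under this assay, only one is a value at all, and it sits at the limit of > 100000 nM in this assay, at which 1 of the 2 values shown sits.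

Compound 3 arises from compound 2 by one change (hydrogen in place of chloro on an aromatic carbon), that is, hydrogen in place of chloro on an aromatic carbon, the position lying between two ring nitrogen atoms, meta to a chloro group, meta to a fused ring and para to a fused ring. Among the compounds with values here, no measured step links compound 2 and compound 3, and compound 2 itself has no number to step from, so no size or direction can be drawn from that pair.

What can be said rests on compound 1, because compound 1 gives > 100000 nM, a limit and not a number. Compound 3 is therefore expected to sit around 150000 nM, with a plausible range from 30000 nM to 600000 nM, and it is expected that the assay may again report only a limit.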

Compound 3, concentration lethal to 50% of the cells: > 100000 nM
Compound 3 ended at the assay's limit (the forecaster's own chance of this, stated with the estimate: 75%); the middle value does not contradict the limit.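

In this assay compound 3 gives > 100000 nM, a limit of the assay and not a number, and compound 2 has no reported result, so no new step can be read between compound 2 and compound 3. The compounds shown leave open what hydrogen in place of chloro on that aromatic carbon does to this read-out.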